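This account rests on a few compounds, and the source may have more. Where it says the series, first, only, none or still open, it means among the compounds named here.

In a functional assay on K562 cells (Homo sapiens) for antiproliferative activity, read by MTT assay, with a stated time of 48 h (on this read-out lower numbers stand for stronger inhibition and higher numbers for weaker inhibition), the measured compounds read as follows:

Compound 1 (`COc1ccc(-c2ccc3c(c2)C(=O)C(=O)N3Cc2ccc(Cl)cc2)cc1`) gives 350 nM here
Compound 2 (`COc1ccc(-c2ccc3c(c2)C(=O)C(=O)N3Cc2cccc(Cl)c2)cc1`) gives 200 nM here
Compound 3 (`COc1ccc(-c2ccc3c(c2)C(=O)C(=O)N3Cc2ccccc2Cl)cc1`) gives 380 nM here

Compound 3 stands within the scatter of both neighbours (a 1.1-fold higher number from compound 1 to compound 3 (0.04 log units; within the scatter); a 1.9-fold higher number from compound 2 to compound 3 (0.28 log units; within the scatter)). Compound 4 (`COc1ccc(-c2ccc3c(c2)C(=O)C(=O)N3Cc2ccccc2OC)cc1`) carries methoxy in place of chloro on an aromatic carbon, ortho to a large group (methoxy in place of chloro on an aromatic carbon). Within the data shown here, no measured step makes this exchange. The nearest evidence is the moving of the chloro, and those steps, including the third (a 1.8-fold lower number from compound 1 to compound 2 (0.24 log units; within the scatter)), all stay within the scatter. In this assay no step beyond the scatter is therefore expected, and these data argue for no direction. The expected step is slight (a 1.1-fold higher number from compound 3 to compound 4 (0.02 log units; within the scatter)). For compound 4 the estimate is 400 nM with an expected range from 160 nM to 1000 nM around it.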

Compound 4, half-maximal inhibitory concentration: 40 nM
Compound 4: the middle estimate sits 10-fold (1.00 log units) above what was measured, outside the stated range (below it).
By their numbers in this assay, from the lowest: compound 4; then compounds 2, 1 and 3 (each within the scatter of the next).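

In this assay, the moves of the chloro had stayed within the scatter, but exchanging chloro for methoxy on this aromatic carbon, ortho to a large group, gives a 9.5-fold lower number from compound 3 to compound 4 (0.98 log units; beyond the scatter). The 2-methoxyphenyl group also separates clearly from the other two chloro isomers, with a 5.0-fold lower number from compound 2 to compound 4 (0.70 log units; beyond the scatter) and an 8.8-fold lower number from compound 1 to compound 4 (0.94 log units; beyond the scatter), so at this place the identity of the group matters more than the position of the chloro did. Nothing available explains this change.

The compounds shown leave open whether methoxy would give the same result at the other two ring positions. They also leave open whether a hydroxyl or an ethoxy could replace it here.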